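This account rests on a few compounds, and the source may have more. Where it says the series, first, only, none or still open, it means among the compounds named here.

Measured so far:
compound 1, `Cc1cccc(-n2nncc2CN2C(=O)C3(C(C#N)=C(N)Oc4c(N)cc5nc6ccccc6nc5c43)c3ccccc32)c1`: > 50000 nM
compound 2, `CCc1ccccc1-n1nncc1CN1C(=O)C2(C(C#N)=C(N)Oc3c(N)cc4nc5ccccc5nc4c32)c2ccccc21`: 17900 nM

In a functional assay on HepG2 cells (Homo sapiens) for antiproliferative activity, read by MTT assay, with a stated time of 48 h (a lower number here means a stronger inhibitor, a higher number a weaker inhibitor), compound 1 gives only > 50000 nM, which is a limit of the measurement and not a number. Compound 2 gives 17900 nM in this assay. Among the measured compounds shown here, the single measured step, an at least 2.7-fold lower number from compound 1 to compound 2 (0.44 log units; beyond the scatter), leaves compound 2 as the only compound with an actual number, the other value being (the limit of > 50000 nM in this assay, at which 1 of the 2 values shown sits).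

Compound 3, `N#CC1=C(N)Oc2c(N)cc3nc4ccccc4nc3c2C12C(=O)N(Cc1cnnn1-c1ccc(F)cc1)c1ccccc12`, differs from compound 2 by 4-fluorophenyl in place of 2-ethylphenyl on an aromatic nitrogen. For the measured compounds named here, only one measured step touches this phenyl group, and it moved the number by at least a modest amount; a 4-fluorophenyl is a third, different pattern, so a step of similar size in either direction cannot be ruled out. The estimate for compound 3 in this assay is 25000 nM, between 8000 nM and 60000 nM. The step this expectation implies is a 1.4-fold higher number from compound 2 to compound 3 (0.15 log units; within the scatter).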

Compound 3, half-maximal inhibitory concentration: > 50000 nM
Compound 3 ended at the assay's limit; the forecaster's own chance of this, stated with the estimate: 35%; middle value at least 2.0-fold (0.30 log units) from the limit.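

The change to 4-fluorophenyl on the aromatic nitrogen gives an at least 2.7-fold higher number from compound 2 to compound 3 (0.44 log units; beyond the scatter), so a change at this one position decides whether this assay returns a number at all. Among the three compounds, only the 2-ethylphenyl group gives a measured value, while 3-methylphenyl and 4-fluorophenyl both end at the assay's limit, which is not a number. The step from compound 1 to compound 3 cannot be read, and how much weaker than compound 2 either compound is stays unknown: the limit of > 50000 nM in this assay, at which 2 of the 3 values shown sit.

Compound 2 differs from the other two in both the group on the phenyl ring and where it sits, so these two effects cannot be separated. A 4-ethylphenyl or 2-fluorophenyl group would pull them apart, and a longer chain such as 2-propylphenyl would show whether the number can fall further.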